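A step from amino to hydrogen at the assay limit

A few compounds are considered here, and "the series" means these few. Any claim that something is new, unique, unknown or untested is made for them only; others in the source may bear on it.

Values in a functional assay on HeLa cells (Homo sapiens) for antiproliferative activity, read by MTT assay, with a stated time of 72 h (a lower number here means a stronger inhibitor, a higher number a weaker inhibitor), follow, each one a limit:
Compound 1 (`COc1cc(-c2ncnn2-c2cccc(F)c2)cc(OC)c1OC`): > 10000 nM (limit)
Compound 2 (`COc1cc(-c2ncnn2-c2ccc(F)cc2)cc(OC)c1OC`): > 10000 nM (limit)
Compound 3 (`COc1cc(-c2ncnn2-c2ccc(N)cc2)cc(OC)c1OC`): > 10000 nM (limit)

Compound 3 stands at a limit and has no number of its own. The set as a whole offers only the limit of > 10000 nM in this assay, at which 3 of the 3 values shown sit, and no measured number, so compound 3 cannot be placed above or below its neighbours.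

The next structure is compound 4 (`COc1cc(-c2ncnn2-c2ccccc2)cc(OC)c1OC`). The change to it is hydrogen in place of amino on an aromatic carbon and the same difference reads 4-aminophenyl to phenyl.

The closest guide is a step that the two limits leave unreadable from compound 2 to compound 3 at the very position that changes here. Two further guides are a step that the two limits leave unreadable from compound 1 to compound 2 and a step that the two limits leave unreadable from compound 1 to compound 3 and neither gives a size. All three steps therefore leave their size and direction open, and none of them brought a number into this assay at all.

No step beyond the scatter is expected, and the estimated change is a step that the limit leaves unreadable from compound 3 to compound 4 with no firm direction. For compound 4 the expected value is 15000 nM with an estimated range from 5000 nM to 40000 nM and a report of only a limit is the likeliest outcome.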

Compound 4, half-maximal inhibitory concentration: > 10000 nM
Compound 4 ended at the assay's limit (the forecaster's own chance of this, stated with the estimate: 80%); the middle value does not contradict the limit.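

Compound 4, like compound 1, compound 2 and compound 3, gives only a limit in this assay, so no step among these four compounds can be read, in size or in direction. What the compounds shown leave open is how any of these changes on the phenyl group would act on a measurable value, since the set holds only this: the limit of > 10000 nM in this assay, at which 4 of the 4 values shown sit.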